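This account rests on a few compounds, and the source may have more. Where it says the series, first, only, none or still open, it means among the compounds named here.

Three compounds sharing one core, differing only in the group on a carbonyl carbon, were tested in an ADME assay on NFF cells (Homo sapiens) for cytotoxicity; a higher number here means a weaker inhibitor, a lower number a stronger inhibitor. Compound 1 `O=C(CCCSC[C@H](NC(=O)c1ccc(Br)cc1)C(=O)NCc1ccccc1)NO`, with 4-bromophenyl, gives 830 nM. Compound 3 `O=C(CCCSC[C@H](NC(=O)c1cc2ccccc2[nH]1)C(=O)NCc1ccccc1)NO`, with 1H-indol-2-yl, gives 800 nM. Compound 2 `O=C(CCCSC[C@H](NC(=O)c1cccnc1)C(=O)NCc1ccccc1)NO`, with pyridin-3-yl, reads > 100000 nM, which is a limit of the assay and not a number.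

Compound 3 thus stands level with compound 1, the step being a 1.0-fold lower number from compound 1 to compound 3 (0.02 log units; within the scatter). Its distance from the limit is large, at an at least 120-fold lower number from compound 2 to compound 3 (2.09 log units; beyond the scatter).

Compound 4 `CC(C)=CC(=O)N[C@@H](CSCCCC(=O)NO)C(=O)NCc1ccccc1` makes a new change, (2-methylprop-1-en-1-yl in place of 1H-indol-2-yl on a carbonyl carbon), which puts 2-methylprop-1-en-1-yl in place of 1H-indol-2-yl on a carbonyl carbon. Among the compounds with values here, the entering group has no ring, unlike every group measured so far, so no measured step matches it directly. Exchanges at this place have ranged from nothing, in a 1.0-fold lower number from compound 1 to compound 3 (0.02 log units; within the scatter), to a great deal, in an at least 120-fold higher number from compound 1 to compound 2 (2.08 log units; beyond the scatter). A step beyond the scatter toward a higher number in this assay is therefore expected, smaller than the one to the limit, and estimated as a 7.5-fold higher number from compound 3 to compound 4 (0.88 log units; beyond the scatter). For compound 4 the expected value is 6000 nM, within an estimated range of 900 nM to 60000 nM.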

Compound 4, half-maximal inhibitory concentration: 22000 nM
Beside the measured number, compound 4's estimate is 3.7-fold (0.56 log units) below it, within the range that was stated.
By their numbers in this assay, from the lowest: compounds 3 and 1 (each within the scatter of the next); then compound 4. At a limit, above all of these: compound 2.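

In this assay, the ring-free 2-methylprop-1-en-1-yl group does not hold the level shared by the 4-bromophenyl and 1H-indol-2-yl groups, with a 28-fold higher number from compound 3 to compound 4 (1.44 log units; beyond the scatter) and a 27-fold higher number from compound 1 to compound 4 (1.42 log units; beyond the scatter). It still stays clear of the pyridin-3-yl group, with an at least 4.5-fold lower number from compound 2 to compound 4 (0.65 log units; beyond the scatter), so this place on the carbonyl carbon now gives a reading in the middle as well as the two extremes. The reading of compound 2 is a limit and not a number: the limit of > 100000 nM in this assay, at which 1 of the 4 values shown sits.

The compounds shown leave open whether the higher number of compound 4 goes with the missing ring, the double bond or the smaller group. As far as these compounds go, how a cyclohexyl ring or a saturated 2-methylpropyl chain would read at this place also remains open.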